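The source may hold more compounds than are shown below. What is called first, only, known or untested is meant among the compounds shown, and "the series" means these compounds.

Measured compounds in an assay on isolated protein for inhibition of Leucine-rich repeat serine/threonine-protein kinase 2 variant G2019S (Homo sapiens), read by TR-FRET and LanthaScreen, with stated times of 50 min and 30 min, in the presence of a further agent that is not named here; a lower number here means a stronger inhibitor, a higher number a weaker inhibitor:
compound 1 `C[C@@H]1CCCN1c1c(C#N)c2c(N)nc(Nc3cn(C)nc3C(F)(F)F)nc2n1C` — 358 nM
compound 2 `C[C@H]1CCCN1c1c(C#N)c2c(N)ncnc2n1C` — 3080 nM
compound 3 `Cc1nn(CC(C)(C)O)cc1Nc1nc(N)c2c(C#N)c(N3CCC[C@H]3C)n(C)c2n1` — 42 nM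

Compound 1 stands second highest of the three numbers; compound 3 gives the lower number and compound 2 the higher, both separated from compound 1 by more than the scatter.

Compound 4 `Cc1c(Nc2nc(N)c3c(C#N)c(N4CCC[C@H]4C)n(C)c3n2)cnn1C` is not yet measured. The change from compound 1 is 1,5-dimethyl-1H-pyrazol-4-yl in place of 1-methyl-3-(trifluoromethyl)-1H-pyrazol-4-yl on a nitrogen on an aromatic ring. For the measured compounds named here, no step between measured compounds isolates this change, so the size is uncertain; a modest shift toward a lower number is expected, near the edge of the scatter, because compound 3 with a methyl-bearing pyrazole gives 42 nM. The estimated step is a 2.0-fold lower number from compound 1 to compound 4 (0.30 log units; within the scatter). For compound 4 the expected value is 180 nM, in the range 50 nM to 650 nM.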

Compound 4, half-maximal inhibitory concentration: 43 nM
The estimate for compound 4 lay 4.2-fold (0.62 log units) above the measured number; the measured number lies below the stated range.
By their numbers in this assay, from the lowest: compounds 3 and 4 (each within the scatter of the next); then compound 1; then compound 2.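

On a nitrogen on an aromatic ring, 1,5-dimethyl-1H-pyrazol-4-yl in place of 1-methyl-3-(trifluoromethyl)-1H-pyrazol-4-yl gives, in this assay, an 8.3-fold lower number from compound 1 to compound 4 (0.92 log units; beyond the scatter), a step beyond the scatter. For the compounds shown here, this is the first step that isolates one place, and it shows that this substituent alone moves the number well beyond the scatter with the shared core unchanged. No measurement shown here accounts for the step. Still open, from the compounds shown here alone, is whether losing the trifluoromethyl or gaining the second methyl carries the step. Also open, going by these compounds, is how a pyrazole bearing an amine or a carboxylic acid would read in this assay on this core.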